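Trifluoromethoxy for trifluoromethyl: what one step may carry

The compounds below may be only part of what the source reports. "The series", "measured", "known", "first", "only" and "open" are said of these compounds alone.

Compound 1: `O=C(Nc1ccc(OC(F)(F)F)cc1)NC1CCN(C(=O)[C@@H]2CCOC2)CC1`, 23 ug/mL
Compound 2: `O=C(Nc1ccc(C(F)(F)F)cc1)NC1CCN(C(=O)[C@@H]2CCOC2)CC1`, 1.4 ug/mL
Compound 3: `CC(C)C(=O)N1CCC(NC(=O)Nc2ccc(C(F)(F)F)c(F)c2)CC1`, 5.9 ug/mL

Of the compounds shown here, three have been measured in a physicochemical assay for solubility, read by mass spectrometry, in phosphate buffer, with a stated time of 24 h, at pH 7.4; a higher number here means a more soluble compound, a lower number a less soluble compound. Compound 2 and compound 1 share a core and differ in one place: trifluoromethoxy in place of trifluoromethyl on an aromatic carbon. That change gave a 16-fold higher number from compound 2 to compound 1 (1.22 log units; beyond the scatter). Compound 3 stands between the two in this assay; the difference between its core and the core of compound 2 is not broken down here.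

Compound 4, `CC(C)C(=O)N1CCC(NC(=O)Nc2ccc(OC(F)(F)F)c(F)c2)CC1`, has not yet been measured. It differs from compound 3 in one place: trifluoromethoxy in place of trifluoromethyl on an aromatic carbon. Among the compounds with values here, this is the same kind of change as the one from compound 2 to compound 1, though the place is not the same word for word: in compound 3 and compound 4 the changed group sits ortho to a fluoro group (1 heavy atom), which the earlier pair does not have. Within the data shown here, with only one measured example of this change, the expectation for compound 4 rests on that example, and on compound 3 as starting point, whose value in this assay was 5.9 ug/mL.

Among the measured compounds shown here, from compound 3 to compound 4 the step is expected to be an 8.5-fold higher number from compound 3 to compound 4 (0.93 log units; beyond the scatter), somewhat smaller than the earlier one given the single precedent. Compound 4 is therefore estimated at 50 ug/mL, with a plausible range from 15 ug/mL to 160 ug/mL.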

Compound 4, solubility: 5.3 ug/mL
For compound 4 the middle estimate is 9.4-fold (0.97 log units) above the measured one; measured number outside the range, below it.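

In this assay the exchange of trifluoromethyl for trifluoromethoxy on an aromatic carbon gave a 1.1-fold lower number from compound 3 to compound 4 (0.05 log units; within the scatter), whereas the same kind of exchange had earlier given a 16-fold higher number from compound 2 to compound 1 (1.22 log units; beyond the scatter), so the large step seen on one core did not carry over to the other. This shows that the size of the step depends on its setting in this series, but two examples do not show which feature of that setting matters: in compound 4 the changed group sits ortho to a fluoro group, which compound 1 does not have, and the two cores also differ elsewhere. Nothing measured here accounts for the difference between the two outcomes.

The compounds shown leave open whether the fluoro group or the remainder of the core decides how far this exchange moves the number, as no pair here separates the two. They also leave open how the exchange would read on a core carrying an amine or a carboxylic acid, and how a nitrile in the same place would compare with trifluoromethyl and trifluoromethoxy.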